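The source may hold more compounds than are shown below. What is called first, only, known or untested is meant among the compounds shown, and "the series" means these compounds.

Measured compounds:

Compound 1 `C=CCNC(=S)NC1=C(C#N)C(c2ccc(Cl)cc2Cl)C2=C(CCCC2=O)N1c1ccc(S(N)(=O)=O)cc1` — 10%
Compound 2 `N#CC1=C(NC(=S)Nc2ccc(Cl)cc2)N(c2ccc(S(N)(=O)=O)cc2)C2=C(C(=O)CCC2)C1c1ccc(Cl)cc1Cl` — 30%
Compound 3 `N#CC1=C(NC(=S)Nc2ccc(Br)cc2)N(c2ccc(S(N)(=O)=O)cc2)C2=C(C(=O)CCC2)C1c1ccc(Cl)cc1Cl` — 50%

These three share one core and differ only in the group on the amide-type nitrogen of the thiourea. In a functional assay on Ehrlich cells (Mus musculus) for cytotoxicity, read by trypan blue exclusion, with a stated time of 2 h, tested at 10 ug/mL (a higher number here means a stronger effect of the compound at the concentration tested, a lower number a weaker effect), compound 3 stands highest of the three numbers, above compound 2 and furthest from compound 1, both of those gaps being beyond the scatter.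

Compound 4 `N#CC1=C(N2C(=O)CCC2=O)N(c2ccc(S(N)(=O)=O)cc2)C2=C(C(=O)CCC2)C1c1ccc(Cl)cc1Cl` has not yet been measured. It differs from compound 3 as follows: a group of 7 heavy atoms (4 carbon, 1 nitrogen, 2 oxygen; one five-membered non-aromatic ring with 1 hetero atom) in place of a group of 11 heavy atoms (7 carbon, 2 nitrogen, 1 sulfur, 1 bromine; one six-membered aromatic ring of carbon only), on a double-bonded ring carbon

The measured steps all concern the same position: a number 20 percentage points higher from compound 1 to compound 2 (beyond the scatter), a number 40 percentage points higher from compound 1 to compound 3 (beyond the scatter) and a number 20 percentage points higher from compound 2 to compound 3 (beyond the scatter). They show that changing what sits on this nitrogen shifts the read-out by a modest to large amount, but none of them puts a 2,5-dioxopyrrolidin-1-yl group in place of the thiourea, so they do not settle the direction for compound 4. Removing the 4-bromophenyl thiourea that gave the highest number is expected to lose some of that gain, so a step of a number 30 percentage points lower from compound 3 to compound 4 (beyond the scatter) is expected. Compound 4 is therefore estimated at 20%, within a range from 5% to 45%.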

Compound 4, a percentage reported as activity, at one concentration (the size of the read-out at that concentration, not a potency): 20%
Compound 4: middle estimate and measured number agree at the digits printed; the range from low to high includes it.
By their numbers in this assay, from the lowest: compounds 1, 4 and 2 (each within the scatter of the next, the first and the last beyond it); then compound 3.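

In this assay, a ring that replaces the whole thiourea arm, the 2,5-dioxopyrrolidin-1-yl group, gives a number 30 percentage points lower from compound 3 to compound 4 (beyond the scatter) and so does not keep the number reached with the 4-bromophenyl thiourea. Set against the two other thioureas, the same change gives a number 10 percentage points lower from compound 2 to compound 4 (within the scatter) and a number 10 percentage points higher from compound 1 to compound 4 (within the scatter), so this ring cannot be told apart from either the allyl or the 4-chlorophenyl thiourea. This position therefore gives a read-out in the same range without any thiourea, and only compound 3 stands clear of compound 4. Nothing measured here explains these differences. Still open, going by these compounds, is what a plain amine at this position would give, and whether a urea carrying the 4-bromophenyl group, with oxygen in place of sulfur, would hold the number of compound 3.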